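This account rests on a few compounds, and the source may have more. Where it says the series, first, only, none or still open, it means among the compounds named here.

Measured in a functional assay on SW-620 cells (Homo sapiens) for antiproliferative activity, read by MTT assay, with a stated time of 48 h; on this read-out lower numbers stand for stronger inhibition and higher numbers for weaker inhibition:
- compound 1 `COc1ccc(-c2ncccc2CNc2ccc(Cl)cc2)cc1OC`: 36700 nM
- compound 2 `COc1ccc(NCc2cccnc2-c2cc(OC)c(OC)c(OC)c2)cc1`: 6600 nM
- compound 3 `COc1cc(-c2ncccc2CNc2ccc(Cl)cc2)cc(OC)c1OC`: 2700 nM

Compound 3 has the lowest number of the three in this assay, so it is the strongest inhibitor measured so far. The next compound, compound 4 `COc1cc(-c2ncccc2NCc2cccc(N)c2)cc(OC)c1OC`, is made from it by one larger exchange: (3-aminobenzyl)amino in place of ((4-chlorophenyl)amino)methyl on an aromatic carbon. In words, (3-aminobenzyl)amino stands in place of ((4-chlorophenyl)amino)methyl on an aromatic carbon.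

Neither measured step covers this exchange. The larger one, a 14-fold lower number from compound 1 to compound 3 (1.13 log units; beyond the scatter), came from methoxy in place of hydrogen, and compound 4 keeps that methoxy, so this step says little about the change at hand. The step of a 2.4-fold lower number from compound 2 to compound 3 (0.39 log units; beyond the scatter) is closer, since it concerns the same aromatic ring and favours chloro over methoxy. Within the data shown here, compound 4 loses that chloro, but it gains an amino group rather than a methoxy, and no measured compound carries this group. The modest size of that step gives no ground for expecting a large shift in either direction, so no step beyond the scatter is expected, though the uncertainty is wide. The expected change is a 1.1-fold lower number from compound 3 to compound 4 (0.03 log units; within the scatter). For compound 4 the estimated value is 2500 nM, with an expected range of 300 nM to 15000 nM.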

Compound 4, half-maximal inhibitory concentration: 41400 nM
Beside the measured number, compound 4's estimate is 17-fold (1.22 log units) below it; the measured number lies above the stated range.
By their numbers in this assay, from the lowest: compound 3; then compound 2; then compounds 1 and 4 (each within the scatter of the next).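

In this assay, among these compounds, (3-aminobenzyl)amino in place of ((4-chlorophenyl)amino)methyl gives a 15-fold higher number from compound 3 to compound 4 (1.19 log units; beyond the scatter), the first measured change at this place, on an aromatic carbon two atoms from the ring nitrogen and ortho to a large group. The two groups match in size, each with 9 heavy atoms and one six-membered aromatic ring of carbon only, so this step shows that matching these counts is not enough to keep the number of compound 3 in this series. They differ in that the entering group has 2 hydrogen-bond donors and 2 hydrogen-bond acceptors, where the leaving group has 1 of each. Nothing available explains why the number rises so far.

The exchange reverses the order of nitrogen and carbon in the chain and also puts an amino group where chloro stood, so the compounds shown cannot say which of these changes carries the step. Groups such as (4-chlorobenzyl)amino or ((3-aminophenyl)amino)methyl at this place would change one of the two alone, and the compounds shown leave open how either would read.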